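Sulfone to Sulfonamide Where Every Value Is a Limit

The compounds below may be only part of what the source reports. "The series", "measured", "known", "first", "only" and "open" are said of these compounds alone.

Compound 1, `CCSCCC12CCC(c3nnc(-c4ccccc4C(F)(F)F)n3C)(CC1)CC2`, in an assay on CHO-K1 cells for inhibition of 11-beta-hydroxysteroid dehydrogenase type 2 (Mus musculus), read by scintillation proximity assay (on this read-out higher numbers stand for weaker inhibition and lower numbers for stronger inhibition), gives only the assay's limit, > 4000 nM.
Compound 2, `Cn1c(-c2ccccc2C(F)(F)F)nnc1C12CCC(CCS(C)(=O)=O)(CC1)CC2`, in this assay gives only a limit, > 4000 nM.
Compound 3, `Cn1c(-c2ccccc2C(F)(F)F)nnc1C12CCC(CCS(=O)(=O)C(C)(C)C)(CC1)CC2`, in this assay gives only a limit, > 4000 nM.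

Compound 3 therefore stands nowhere on a scale of numbers: its value is a limit, and so are the two others, which is the whole of the evidence here: the limit of > 4000 nM in this assay, at which 3 of the 3 values shown sit. The three steps among the measured compounds are a step that the two limits leave unreadable from compound 1 to compound 2, a step that the two limits leave unreadable from compound 1 to compound 3 and a step that the two limits leave unreadable from compound 2 to compound 3; none of them can be read as a size, because both ends of each sit at the limit (the limit of > 4000 nM in this assay, at which 3 of the 3 values shown sit).

Compound 4, `Cn1c(-c2ccccc2C(F)(F)F)nnc1C12CCC(CNS(C)(=O)=O)(CC1)CC2`, differs from compound 3 by methanesulfonamido in place of ((tert-butyl)sulfonyl)methyl on a saturated chain carbon bound to a saturated ring carbon. Within the data shown here, no measured step shows how such a change acts in this assay; the three steps that concern the same saturated chain carbon all end at the limit. The expectation for compound 4 thus rests only on all measured neighbours reaching the limit, and the expected step from compound 3 to compound 4 is a step that the limit leaves unreadable from compound 3 to compound 4, meaning nothing readable. Compound 4 is expected to give about 8000 nM, within 2000 nM to 40000 nM, most likely reported again as a limit.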

Compound 4, half-maximal inhibitory concentration: > 4000 nM
Compound 4: only a limit was reported (the forecaster's own chance of this, stated with the estimate: 80%); the middle value is on the limit's open side.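

No new step can be read from compound 4: its comparisons with compound 1, compound 2 and compound 3 have no size, because each compares one limit with another: the limit of > 4000 nM in this assay, at which 4 of the 4 values shown sit. The compounds shown leave open how weak each one truly is in this assay, and whether any change on this chain would give a measurable number.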